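This account rests on a few compounds, and the source may have more. Where it says the series, first, only, none or still open, it means among the compounds named here.

Of the compounds shown here, three built on one shared core have been measured in a functional assay on blood for antagonist activity at thromboxane A2 receptor (Homo sapiens); on this read-out lower numbers stand for tighter binding and higher numbers for weaker binding. Compound 1 `O=C(O)CC/C=C\CO[C@H]1C(OCc2ccc(-c3ccccc3)cc2)CC[C@@H]1N1CCCCCC1` gives 12.6 nM. Compound 2 `CS(=O)(=O)Nc1ccccc1-c1ccc(COC2CC[C@H](N3CCCCCC3)[C@H]2OC/C=C\CCC(=O)O)cc1` gives 10 nM, and compound 3 `CS(=O)(=O)Nc1cccc(-c2ccc(COC3CC[C@H](N4CCCCCC4)[C@H]3OC/C=C\CCC(=O)O)cc2)c1` gives 12.6 nM. Compound 3 stands level with compound 1, the two together holding the highest numbers of the three, and compound 2 lies within the scatter of both, as the steps of no change at the digits printed from compound 1 to compound 3 (within the scatter) and a 1.3-fold higher number from compound 2 to compound 3 (0.10 log units; within the scatter) show. Compound 4 `CC(=O)NCc1ccc(-c2ccc(COC3CC[C@H](N4CCCCCC4)[C@H]3OC/C=C\CCC(=O)O)cc2)cc1` differs from compound 3 in one place: 4-(acetamidomethyl)phenyl in place of 3-(methanesulfonamido)phenyl on an aromatic carbon. Among the measured compounds shown here, no measured step swaps one substituted phenyl for another of this kind, but the steps of a 1.3-fold lower number from compound 1 to compound 2 (0.10 log units; within the scatter) and no change at the digits printed from compound 1 to compound 3 (within the scatter) show that adding a group on this ring has so far changed little. The expected step of no change at the digits printed from compound 3 to compound 4 (within the scatter) therefore stays within the scatter. Compound 4 is estimated at 12.6 nM, with a range from 4 nM to 40 nM.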

Compound 4, dissociation constant: 2.51 nM
Beside the measured number, compound 4's estimate is 5.0-fold (0.70 log units) above it, outside the stated range (below it).
By their numbers in this assay, from the lowest: compound 4; then compounds 2, 1 and 3 (each within the scatter of the next).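

In this assay, 4-(acetamidomethyl)phenyl gives a 5.0-fold lower number from compound 3 to compound 4 (0.70 log units; beyond the scatter), a 4.0-fold lower number from compound 2 to compound 4 (0.60 log units; beyond the scatter) and a 5.0-fold lower number from compound 1 to compound 4 (0.70 log units; beyond the scatter). This position therefore does respond to the group placed on it: the two methanesulfonamido groups stayed within the scatter of hydrogen, while acetamidomethyl moved beyond it. No measurement shown explains this difference. The compounds shown leave open whether the lower number follows the acetamidomethyl group itself or its place para to a large group. A 4-(methanesulfonamido)phenyl or a 3-(acetamidomethyl)phenyl group would help separate the two.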